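A few compounds are considered here, and "the series" means these few. Any claim that something is new, unique, unknown or untested is made for them only; others in the source may bear on it.

In a functional assay on HepG2 cells (Homo sapiens) for cytotoxicity, read by MTT assay, with a stated time of 24 h (a lower number here means a stronger inhibitor, a higher number a weaker inhibitor), compound 1 `COc1ccc(/C=C2\CN(C)C/C(=C\c3ccccc3F)C2=O)cc1` gives 12300 nM while compound 2 `COc1cc(/C=C2\CN(C)C/C(=C\c3ccccc3F)C2=O)cc(OC)c1OC` gives 670 nM and compound 3 `COc1cc(/C=C2\CN(C)C/C(=C\c3ccc(F)cc3)C2=O)cc(OC)c1` gives 6140 nM as its reading. Compound 3 thus lies within the usual scatter of compound 1, and compound 2 stands clearly lower than compound 3. Compound 4 `COc1cc(/C=C2\CN(C)C/C(=C\c3cccc([N+](=O)[O-])c3)C2=O)cc(OC)c1` carries 3-nitrophenyl in place of 4-fluorophenyl on a double-bonded chain carbon bound to a double-bonded ring carbon, and 3-nitrophenyl in place of 4-fluorophenyl on a double-bonded chain carbon bound to a double-bonded ring carbon counts that change. For the measured compounds named here, no two measured compounds differ in one place only, so nothing measured shows this swap directly. A shift within the scatter is expected, with no firm direction, and the estimated step of a 1.4-fold lower number from compound 3 to compound 4 (0.13 log units; within the scatter) is therefore small. Compound 4 is estimated at 4500 nM with an expected range from 1300 nM to 15000 nM in this measurement.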

Compound 4, half-maximal inhibitory concentration: 1840 nM
Compound 4: the middle estimate sits 2.4-fold (0.39 log units) above what was measured, and the stated range covers the measured number.
By their numbers in this assay, from the lowest: compound 2; then compound 4; then compounds 3 and 1 (each within the scatter of the next).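

In this assay, 3-nitrophenyl in place of 4-fluorophenyl on the double-bonded chain carbon gives a 3.3-fold lower number from compound 3 to compound 4 (0.52 log units; beyond the scatter). For the compounds shown here, this is the first direct comparison at this position, and it shows that with the rest of the molecule held the same, the group here can shift the reading by more than the scatter. No measured evidence bears on the cause of this shift. Still open, going by these compounds, is whether 4-nitrophenyl would read like 3-nitrophenyl, and how a phenyl ring carrying an amine or a carboxylic acid would read here.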